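Mirror Image of a Bicyclic Lactone in an EL4 Assay

A few compounds are considered here, and "the series" means these few. Any claim that something is new, unique, unknown or untested is made for them only; others in the source may bear on it.

Measured so far:
compound 1 `C[C@H]1N=C2C[C@H]3C[C@H](C3(C)C)[C@@]2(C)OC1=O` — 27000 nM
compound 2 `CC1(C)[C@H]2CC[C@]1(C)[C@H]1OC(=O)CN=C21` — 82000 nM
compound 3 `CC1(C)N=C2C[C@H]3C[C@H](C3(C)C)[C@@]2(C)OC1=O` — 149000 nM

Of the compounds shown here, three have been tested in a functional assay on EL4 cells (Mus musculus) for antiproliferative activity, read by sulforhodamine B assay, with a stated time of 48 h; on this read-out higher numbers stand for weaker inhibition and lower numbers for stronger inhibition. Among them compound 1 stands at the lowest number: compound 2 sits at a higher number, and the gap between them lies beyond the scatter, while compound 3 sits higher still, also beyond the scatter. On this read-out compound 1 is therefore the strongest inhibitor of the three, though all three act only at high concentration.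

Compound 4 `C[C@@H]1N=C2C[C@@H]3C[C@@H](C3(C)C)[C@]2(C)OC1=O` has not been measured. It is the mirror image of compound 1: the two compounds have the same atoms and bonds and differ only in configuration as drawn: 4 of 4 stereo elements differ (all stereocentres are inverted: mirror images); a stereocentre at a saturated ring carbon is drawn R in compound 1 and S in compound 4; a stereocentre at a saturated ring carbon is drawn R in compound 1 and S in compound 4; a stereocentre at a saturated ring carbon is drawn R in compound 1 and S in compound 4; a stereocentre at a saturated ring carbon is drawn R in compound 1 and S in compound 4. For the measured compounds named here, no pair of measured compounds differs in one place, so no measured step gives a direct guide to the size of such a change. A full inversion of configuration can leave an antiproliferative read-out of this kind unchanged or can weaken it; nothing in the present set distinguishes the two cases. The expectation is a modest loss, with a wide range around it.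

Compound 4 is expected to give about 45000 nM in this assay, within 12000 nM to 180000 nM, which would be an estimated step of a 1.7-fold higher number from compound 1 to compound 4 (0.22 log units; within the scatter).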

Compound 4, half-maximal inhibitory concentration: 145000 nM
The estimate for compound 4 lay 3.2-fold (0.51 log units) below the measured number, and the stated range covers the measured number.
By their numbers in this assay, from the lowest: compound 1; then compounds 2, 4 and 3 (each within the scatter of the next).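

In this assay, for the compounds shown here, the mirror pair gives the first step in this set that can be read, a 5.4-fold higher number from compound 1 to compound 4 (0.73 log units; beyond the scatter), and it shows that the read-out responds to configuration alone, with atoms and bonds unchanged. Going by these compounds alone, no two of the earlier compounds differed in one place, so they could not separate an effect of configuration from one of constitution, whereas here the gap has a single source, because only one thing sets the pair apart: the fact that compounds 1 and 4 differ only in the configuration as drawn. The configuration of compound 1 is thus the favoured one of the two, though compound 1 still acts only at a high concentration, 27000 nM.

Since all stereocentres are inverted together, the compounds shown leave open which of them carries the difference and whether inverting only some of them would give a smaller step. They also leave open whether the preference for the configuration of compound 1 would persist with a further group, such as an amine or a carboxylic acid, on the shared core, and whether the mirror images of compound 2 and compound 3 would show a similar step.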